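A few compounds are considered here, and "the series" means these few. Any claim that something is new, unique, unknown or untested is made for them only; others in the source may bear on it.

Three close relatives of one core were tested in a functional assay on L1210 cells (Mus musculus) for antiproliferative activity; on this read-out lower numbers stand for stronger inhibition and higher numbers for weaker inhibition. Compound 1 `CSc1nc2c(C)nsc2n1[C@H]1C[C@H](O)[C@@H](CO)O1` carries a methylsulfanyl group; in this assay compound 1 reaches only the assay limit of > 100000 nM. Compound 2 `Cc1nsc2c1nc(SCc1ccccc1)n2[C@H]1C[C@H](O)[C@@H](CO)O1` differs from compound 1 by phenyl in place of hydrogen on a saturated chain carbon bound to a sulfur, and in this assay compound 2 also stops at the limit of > 100000 nM. The step that the two limits leave unreadable from compound 1 to compound 2 therefore cannot be read. Compound 3 `CSc1nc2c(C)nsc2n1[C@@H]1O[C@H](CO)[C@@H](O)[C@@H]1O` differs from compound 1 by hydroxy in place of hydrogen on a saturated ring carbon; in this assay compound 3 likewise gives only the limit of > 100000 nM, so a step that the two limits leave unreadable from compound 1 to compound 3 stays unreadable too. Compound 4 `Cc1nsc2c1nc(SCc1ccccc1)n2[C@@H]1O[C@H](CO)[C@@H](O)[C@@H]1O` differs from compound 3 by the same change, (phenyl in place of hydrogen on a saturated chain carbon bound to a sulfur). Because (the limit of > 100000 nM in this assay, at which 3 of the 3 values shown sit), no shift is expected from this change, and the step that the limit leaves unreadable from compound 3 to compound 4 is an estimate resting on that. Compound 4 is expected to give around 200000 nM, in a range from 50000 nM to 1000000 nM.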

Compound 4, half-maximal inhibitory concentration: > 100000 nM
Compound 4 was reported as a limit; the forecaster's own chance of this, stated with the estimate: 85%; the middle value is on the limit's open side.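

Compound 4 gives only a limit, as do compound 1, compound 2 and compound 3, so no step among these compounds can be read: the limit of > 100000 nM in this assay, at which 4 of the 4 values shown sit.

On these data alone, whether phenyl or hydroxy in place of hydrogen changes activity at all in this assay stays open.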